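This account rests on a few compounds, and the source may have more. Where it says the series, first, only, none or still open, it means among the compounds named here.

Of the compounds shown here, three from this series have been tested in an ADME assay on HepG2 cells (Homo sapiens) for cytotoxicity, read by MTT assay, with a stated time of 24 h; on this read-out higher numbers stand for lower toxicity in this test and lower numbers for higher toxicity in this test. Compound 1, `Clc1ccc2c(-n3cc(-c4ccccc4)nn3)ccnc2c1`, carries only the bare triazole-linked core and gives 574000 nM. Compound 2, `COc1ccc(C(=O)OCCCc2cn(-c3ccnc4cc(Cl)ccc34)nn2)cc1`, extends the triazole through a three-carbon ester linker to a methoxy-bearing aryl group and gives 347000 nM. Compound 3, `CCc1ccc(C(=O)OCc2cn(-c3ccnc4cc(Cl)ccc34)nn2)cc1`, uses a one-carbon ester linker to a 4-ethylphenyl group. Going by the values given here, for compound 3 this assay reports only a limit, > 2550000 nM, so no number is fixed for it; it is the one compound at the limit of > 2550000 nM in this assay, at which 1 of the 3 values shown sits. Among the compounds with values here, none of these three differ from one another in a single place, so no step between measured compounds can be counted.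

Compound 4, `CC(C)(C)c1ccc(C(=O)OCc2cn(-c3ccnc4cc(Cl)ccc34)nn2)cc1`, is the next compound. It differs from compound 3 by tert-butyl in place of ethyl on an aromatic carbon. With compound 3 standing at a limit, the step from compound 3 to compound 4 is expected to be small or none beyond the scatter, and it is estimated to leave the read-out near the top of the range. Compound 4 is therefore expected to give about 2000000 nM, within roughly 600000 nM to 5000000 nM, with a fair chance that this assay again returns only a limit for it.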

Compound 4, half-maximal cytotoxic concentration: > 2380000 nM
Compound 4 ended at the assay's limit (the forecaster's own chance of this, stated with the estimate: 55%); middle value at least 1.1-fold (0.07 log units) from the limit.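

Compound 3 and compound 4 both ended at limits in this assay, so the step from one to the other cannot be read. The compounds shown leave open what either compound's actual value is, and whether tert-butyl in place of ethyl changes the read-out at all.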